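This account rests on a few compounds, and the source may have more. Where it says the series, first, only, none or still open, it means among the compounds named here.

Compound 2 `CCCS(=O)(=O)Nc1ccc(F)c(C(=O)c2n[nH]c3ncc(-c4cccc(O)c4)cc23)c1F` gives 2.2% in an assay for binding affinity to dual specificity mitogen-activated protein kinase kinase 4 (Homo sapiens), read by KINOMEscan, tested at 100 nM (on this read-out higher numbers stand for a weaker effect at the one concentration tested and lower numbers for a stronger effect), the lowest of the two numbers available, with compound 1 `CCCS(=O)(=O)Nc1ccc(F)c(C(=O)c2n[nH]c3ncc(-c4ccc(OC)cc4)cc23)c1F` nearest at 4.2%; the step of a number 2 percentage points lower from compound 1 to compound 2 (within the scatter) is within the scatter. Compound 3 `CCCS(=O)(=O)Nc1ccc(F)c(C(=O)c2n[nH]c3ncc(-c4ccc(Cl)cc4Cl)cc23)c1F` differs from compound 2 by 2,4-dichlorophenyl in place of 3-hydroxyphenyl on an aromatic carbon. No measured step involves a 2,4-dichlorophenyl, and the only step shown bears on a different exchange, so it is expected to stay within the scatter: a number 5.8 percentage points higher from compound 2 to compound 3 (within the scatter), given the uncertainty of an untested exchange. Compound 3 is estimated at 8%, within 1% to 35%.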

Compound 3, a percentage reported as activity, at one concentration (the size of the read-out at that concentration, not a potency): 22%
The estimate for compound 3 lay 14 percentage points below the measured number; the range from low to high includes it.
By their numbers in this assay, from the lowest: compounds 2 and 1 (each within the scatter of the next); then compound 3.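

Exchanging 3-hydroxyphenyl for 2,4-dichlorophenyl gives a number 19.8 percentage points higher from compound 2 to compound 3 (beyond the scatter), and exchanging 4-methoxyphenyl for it gives a number 17.8 percentage points higher from compound 1 to compound 3 (beyond the scatter). In this assay this aromatic carbon therefore does respond to the group it carries, which the step between the two earlier groups did not show, and the weaker effect at the one concentration tested goes with 2,4-dichlorophenyl. Nothing available explains this difference.

From the compounds shown here alone, it remains open whether a phenyl bearing a single chlorine, or one bearing an amine, would read like compound 1 and compound 2 or like compound 3.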